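Swapping the Aryl Group on a Hydroxamic Acid Core

This account rests on a few compounds, and the source may have more. Where it says the series, first, only, none or still open, it means among the compounds named here.

Measured so far:
compound 1 `Cc1cc(-c2nnc(Sc3c(F)cc(C(=O)NO)cc3F)n2C)nn1C`: 6 nM
compound 2 `O=C(NO)c1ccc(Cn2nnc(-c3cccc(S(F)(F)(F)(F)F)c3)n2)cc1`: 26 nM
compound 3 `Cn1c(Sc2c(F)cc(C(=O)NO)cc2F)nnc1-c1ncccc1F`: 6 nM

In an assay on Sf9 cells for inhibition of protein deacetylase HDAC6 (Homo sapiens), read by fluorescence (a higher number here means a weaker inhibitor, a lower number a stronger inhibitor), compound 3 gives 6 nM, level with compound 1 within the scatter; together these are the lowest of the three numbers, while compound 2 gives a number that is clearly higher, beyond the scatter. Compound 4 `Cn1c(Sc2c(F)cc(C(=O)NO)cc2F)nnc1-c1cccnn1` differs from compound 3 in one place: pyridazin-3-yl in place of 3-fluoropyridin-2-yl on an aromatic carbon. Among the compounds with values here, one measured step bears on this kind of change, the exchange of the aromatic group at the same position: no change at the digits printed from compound 1 to compound 3 (within the scatter). That step stayed within the scatter, so the step of a 1.2-fold higher number from compound 3 to compound 4 (0.07 log units; within the scatter) is likewise expected to show no change beyond the scatter. Compound 4 is therefore estimated at 7 nM, expected to fall between 3 nM and 18 nM.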

Compound 4, half-maximal inhibitory concentration: 13 nM
Beside the measured number, compound 4's estimate is 1.9-fold (0.27 log units) below it; the measured number falls inside the stated range.
By their numbers in this assay, from the lowest: compounds 1 and 3 (each within the scatter of the next); then compounds 4 and 2 (each within the scatter of the next).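

In this assay, within the data shown here, pyridazin-3-yl gives a 2.2-fold higher number from compound 3 to compound 4 (0.34 log units; beyond the scatter) and a 2.2-fold higher number from compound 1 to compound 4 (0.34 log units; beyond the scatter), the first changes at this position to pass the scatter, though both are modest. The position is therefore not indifferent to its aromatic group, even though 3-fluoropyridin-2-yl and 1,5-dimethyl-1H-pyrazol-3-yl stood level. Nothing at hand explains this step. Pyridazin-3-yl differs from 3-fluoropyridin-2-yl in both its ring nitrogen atoms and its lack of fluorine, and which of these matters stays open. As far as these compounds go, how plain pyridin-2-yl or a non-aromatic morpholine would compare here is also open.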